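Swapping Methoxy for Fluoro on a Melatonin Ligand

The compounds below may be only part of what the source reports. "The series", "measured", "known", "first", "only" and "open" are said of these compounds alone.

Among the compounds with values here, compound 1 `COc1cccc(CCCNC(C)=O)c1` is one of three compounds measured in an assay for binding affinity to melatonin receptor (Gallus gallus) (on this read-out lower numbers stand for stronger inhibition and higher numbers for weaker inhibition), where compound 1 gives 63 nM. Among the three numbers it stands second highest. Compound 2 `CCCC(=O)NCCCc1cccc(OC)c1` gives 5.5 nM in this assay, and compound 3 `CCC(=O)NCCCCc1ccc(OC)cc1` gives 1400 nM. Within the data shown here, the only one-place step between measured compounds runs an 11-fold lower number from compound 1 to compound 2 (1.06 log units; beyond the scatter), and it concerns the acyl side of the amide: ethyl in place of hydrogen on a saturated chain carbon bound to a carbonyl carbon.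

Compound 4 `CC(=O)NCCCc1cccc(F)c1` has not yet been measured. It differs from compound 1 in a single place: fluoro in place of methoxy on an aromatic carbon. Among the measured compounds shown here, no measured step touches this part of the molecule; the step from compound 1 to compound 2 changes the other end of the chain, so it says nothing about the aromatic substituent. The data therefore give no direct guide to the size or direction of the effect, and any expectation must carry a wide range. The expected step is a 2.4-fold higher number from compound 1 to compound 4 (0.38 log units; beyond the scatter), leaning toward a weaker number but far from certain. Compound 4 is estimated to give 150 nM in this assay, within a range from 25 nM to 1500 nM.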

Compound 4, inhibition constant: 1920 nM
Beside the measured number, compound 4's estimate is 13-fold (1.11 log units) below it; measured number above the stated range.
By their numbers in this assay, from the lowest: compound 2; then compound 1; then compounds 3 and 4 (each within the scatter of the next).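

In this assay, the change of fluoro in place of methoxy on an aromatic carbon gives a 30-fold higher number from compound 1 to compound 4 (1.48 log units; beyond the scatter) and counts as a large step, so the substituent at this end of the molecule clearly matters. Within the data shown here, until now, the only one-place step was an 11-fold lower number from compound 1 to compound 2 (1.06 log units; beyond the scatter) on the acyl side of the amide; both steps are large but run in opposite directions, which shows that the numbers respond to changes at either end of the chain. The swap also replaces two heavy atoms, one of them a hydrogen-bond acceptor, with a single fluorine, but nothing measured here gives a reason for the loss.

With only methoxy and fluoro compared at this position, one step cannot show whether the oxygen, the methyl carbon or the fluorine itself accounts for the change, and groups such as hydroxy, ethoxy or chloro could help to separate these possibilities. On these data alone, it also remains open whether fluoro in place of methoxy would have a similar effect on compound 2, with its longer acyl chain.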